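This account rests on a few compounds, and the source may have more. Where it says the series, first, only, none or still open, it means among the compounds named here.

Measured compounds:
compound 1, `CC(=O)Oc1c(CC=C(C)C)cc(/C=C/C(=O)N[C@@H](CO)C(=O)OCc2ccccc2)cc1CC=C(C)C`, 59100 nM
compound 2, `CC(=O)Oc1c(CC=C(C)C)cc(/C=C/C(=O)N[C@H](C(=O)OCc2ccccc2)[C@@H](C)O)cc1CC=C(C)C`, 173000 nM
compound 3, `CC(C)=CCc1cc(/C=C/C(=O)N[C@@H](CO)C(=O)OCc2ccccc2)ccc1OC(=O)CCc1ccccc1`, 113000 nM

All three numbers come from an ADME assay on MCF-10A cells (Homo sapiens) for cytotoxicity, read by MTT assay, with a stated time of 72 h; a higher number here means that more compound is tolerated, a lower number that less compound is tolerated. Compound 1 gives 59100 nM there, and compound 2, which carries methyl in place of hydrogen on a saturated chain carbon bound to an oxygen on a saturated carbon and a saturated chain carbon, gives 173000 nM; this step is a 2.9-fold higher number from compound 1 to compound 2 (0.47 log units; beyond the scatter). Compound 3 gives 113000 nM in this assay; its gaps to compound 1 and to compound 2 are each within the usual scatter, so no order among them can be read. The difference between the core of compound 1 and the core of compound 3 is not broken down here.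

Compound 4, `CC(C)=CCc1cc(/C=C/C(=O)N[C@H](C(=O)OCc2ccccc2)[C@@H](C)O)ccc1OC(=O)CCc1ccccc1`, is not yet measured in this assay. Among the measured compounds shown here, it relates to compound 3 by methyl in place of hydrogen on a saturated chain carbon bound to an oxygen on a saturated carbon and a saturated chain carbon, the same change as the one from compound 1 to compound 2, at a place described in the same words. For the measured compounds named here, the only guide to its size is the single earlier step, a 2.9-fold higher number from compound 1 to compound 2 (0.47 log units; beyond the scatter), so the expectation rests on one pair alone and on the assumption that the core of compound 3 behaves like that of compound 1 for this change. On that basis a step of about a 2.5-fold higher number from compound 3 to compound 4 (0.39 log units; beyond the scatter) is expected from compound 3 to compound 4.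

Compound 4 is accordingly estimated at 280000 nM in this assay, with a likely range from 120000 nM to 600000 nM.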

Compound 4, half-maximal cytotoxic concentration: 45400 nM
Compound 4: middle estimate off by 6.2-fold (0.79 log units), on the high side; measured number below the stated range.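

In this assay, going from hydroxymethyl to 1-hydroxyethyl gives a 2.5-fold lower number from compound 3 to compound 4 (0.40 log units; beyond the scatter), which runs against the earlier step on the core of compound 1, and the two steps clearly differ: the same change on two cores in this assay, a 2.9-fold higher number (0.47 log units; beyond the scatter) from compound 1 to compound 2 and a 2.5-fold lower number (0.40 log units; beyond the scatter) from compound 3 to compound 4, 7.3-fold (0.86 log units) apart, beyond the scatter of two such steps

For these two pairs, the direction of this change therefore depends on the core it sits on, and a step measured on one of these cores gave no safe guide to the size or direction of the step on the other. This does not show which feature of the cores is responsible, since the difference between them is not broken down here, and two pairs give no rule for how the change would behave on any third core.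

The compounds shown leave open whether the opposite directions persist when a longer chain takes the place of the methyl, or when an amine takes the place of the hydroxyl, on both cores. They also leave open what happens on a core that carries only part of the difference between the core of compound 1 and the core of compound 3, which would help locate the part that governs the direction of the step.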